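Working notes: bromo in place of chloro, compound 4

The source may hold more compounds than are shown below. What is called first, only, known or untested is meant among the compounds shown, and "the series" means these compounds.

- compound 1 (`COc1cccc(/C=C2\CCC/C(=C\c3cccc(Br)c3)C2=O)c1OC`) 23900 nM
- compound 2 (`COc1cccc(/C=C2\CCC/C(=C\c3cccc(O)c3)C2=O)c1OC`) 19300 nM
- compound 3 (`COc1ccc(/C=C2\CCC/C(=C\c3ccc(Cl)cc3)C2=O)cc1OC`) 11200 nM

In an ADME assay on NHDF cells (Homo sapiens) for cytotoxicity, read by MTT assay, with a stated time of 72 h (a higher number here means a weaker inhibitor, a lower number a stronger inhibitor), compound 3 gives 11200 nM and stands within the scatter of compound 2 but beyond the scatter from compound 1, which carries the higher number.

Compound 4 (`COc1ccc(/C=C2\CCC/C(=C\c3ccc(Br)cc3)C2=O)cc1OC`) keeps the core of compound 3 and differs in one place: bromo in place of chloro on an aromatic carbon on an aromatic carbon, para to a large group, so that 4-chlorophenyl becomes 4-bromophenyl.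

Among the compounds with values here, only one measured step exists, a 1.2-fold lower number from compound 1 to compound 2 (0.09 log units; within the scatter) with hydroxy in place of bromo on an aromatic carbon. It involves bromo but not chloro, so it bears on the change only loosely. Within the data shown here, compound 1 and compound 3 hold bromo and chloro, yet they differ in more than one place, and no measured pair isolates this exchange. On that thin evidence, no step beyond the scatter and no particular direction is expected in this assay for this exchange.

The estimate amounts to a 1.0-fold lower number from compound 3 to compound 4 (0.01 log units; within the scatter) as the expected step, which stays within the scatter. For compound 4 the expected value is 11000 nM with an estimated range from 6000 nM to 20000 nM as the working figure.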

Compound 4, half-maximal inhibitory concentration: 13100 nM
Beside the measured number, compound 4's estimate is 1.2-fold (0.08 log units) below it, within the range that was stated.
By their numbers in this assay, from the lowest: compounds 3, 4, 2 and 1 (each within the scatter of the next, the first and the last beyond it).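

Working notes on the series after compound 4: the pair compound 3 and compound 4 is the first to isolate this exchange, which the earlier compounds could only touch through pairs differing in more than one place. In this assay, bromo in place of chloro on an aromatic carbon of the six-membered ring, para to a large group, gives a 1.2-fold higher number from compound 3 to compound 4 (0.07 log units; within the scatter). On the core shared by this pair, 4-chlorophenyl and 4-bromophenyl therefore cannot be told apart in this read-out, so at this position the exchange of one of these halogens for the other shows no effect that can be separated from the scatter, and no measurement at hand offers an explanation for this.

Still open, as far as these compounds go, is whether a group of another kind at this same place, such as an amine or a carboxylic acid, would give a step beyond the scatter from compound 3. Also open is whether the exchange reads the same way on the core of compound 1, since no chloro counterpart of that compound stands in the series shown here.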